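The source may report more compounds than this note shows. Statements on the series, on what has been measured and on what is new or still open speak of the compounds shown alone.

In a functional assay on HeLa cells (Homo sapiens) for antiproliferative activity, read by MTT assay, with a stated time of 72 h (on this read-out higher numbers stand for weaker inhibition and lower numbers for stronger inhibition), three amides sharing one core have been measured. Compound 1 `C/C=C/C(=O)Nc1cccc(Oc2nc(Nc3ccn(C)n3)nc3c2CSCC3)c1` gives > 50000 nM, which is a limit of the assay. Compound 3 `C=C(F)C(=O)Nc1cccc(Oc2nc(Nc3ccn(C)n3)nc3c2CSCC3)c1` gives > 50000 nM, also a limit and not a number. Going by the values given here, compound 2 `CC(C)/C=C/C(=O)Nc1cccc(Oc2nc(Nc3ccn(C)n3)nc3c2CSCC3)c1` gives 40100 nM, the only actual number among the three. Compound 3 therefore stands at the limit of > 50000 nM in this assay, at which 2 of the 3 values shown sit.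

Compound 4 `C=C(C)C(=O)Nc1cccc(Oc2nc(Nc3ccn(C)n3)nc3c2CSCC3)c1` differs from compound 3 by methyl in place of fluoro on a double-bonded chain carbon bound to a carbonyl carbon. Among the compounds with values here, the steps that bear on this change are those on the same carbonyl carbon. These are an at least 1.2-fold lower number from compound 1 to compound 2 (0.09 log units; that floor lies within the scatter), an at least 1.2-fold higher number from compound 2 to compound 3 (0.09 log units; that floor lies within the scatter) and a step that the two limits leave unreadable from compound 1 to compound 3. None of them shows a change beyond the scatter, so no step beyond the scatter is expected in this assay, and no direction can be favoured. The expected step is an at least 1.1-fold lower number from compound 3 to compound 4 (0.04 log units; that floor lies within the scatter). Compound 4 is estimated at 45000 nM, with an expected range from 20000 nM to 80000 nM.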

Compound 4, half-maximal inhibitory concentration: > 50000 nM
Compound 4: only a limit was reported; the forecaster's own chance of this, stated with the estimate: 55%; middle value at least 1.1-fold (0.04 log units) away from the limit.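

In this assay compound 4 gives > 50000 nM, which is a limit of the assay and not a number. Methyl in place of fluoro on a double-bonded chain carbon bound to a carbonyl carbon thus still gives no measurable value, and the series stays mostly at one point: the limit of > 50000 nM in this assay, at which 3 of the 4 values shown sit. The only readable new step is an at least 1.2-fold higher number from compound 2 to compound 4 (0.09 log units; that floor lies within the scatter), and the other new steps have limits at both ends and cannot be read.

The compounds shown leave open whether an amine or a longer chain at this place would give a number rather than a limit in this assay. They also leave open how far the true values of compound 3 and compound 4 lie from each other.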